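Double-bond geometry and cytotoxicity: compound 3 to compound 4

The source may hold more compounds than are shown below. What is called first, only, known or untested is meant among the compounds shown, and "the series" means these compounds.

Measured in a functional assay on K562 cells (Homo sapiens) for cytotoxicity; a lower number here means a stronger inhibitor, a higher number a weaker inhibitor:
compound 1 `COc1c(O)cc2c3c1C[C@@H](C)C[C@H](OC)[C@H](O3)[C@@H](C)/C=C(\C)[C@H](OC(N)=O)[C@@H](OC)CC/C=C(\C)C(=O)N2`: 43000 nM
compound 2 `COc1c(O)cc2c3c1C[C@@H](C)C[C@H](OC)[C@H](O3)[C@@H](C)/C=C(\C)[C@H](OC(N)=O)[C@@H](OC)/C=C\C=C(/C)C(=O)N2`: 14000 nM
compound 3 `COc1c(O)cc2c3c1C[C@@H](C)C[C@H](OC)[C@H](O3)[C@@H](C)/C=C(\C)[C@H](OC(N)=O)[C@@H](OC)/C=C/C=C(\C)C(=O)N2`: 43000 nM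

Compound 3, at 43000 nM, stands level with compound 1 at the digits given, and together they carry the highest number of the three. Compound 2 is the one clear departure, and the series offers a single measured step, a 3.1-fold higher number from compound 2 to compound 3 (0.49 log units; beyond the scatter). That step is attributable to the fact that compounds 2 and 3 differ only in the configuration as drawn, so the configuration of one double bond is enough to move the number beyond the scatter.

The next compound is compound 4 `COc1c(O)cc2c3c1C[C@@H](C)C[C@H](OC)[C@H](O3)[C@@H](C)/C=C(\C)[C@H](OC(N)=O)[C@@H](OC)/C=C\C=C(\C)C(=O)N2`. The change is the two compounds have the same atoms and bonds and differ only in configuration as drawn: 2 of 9 stereo elements differ; a double bond is drawn E in compound 3 and Z in compound 4; a double bond is drawn E in compound 3 and Z in compound 4. The measured step bears on only part of this, since it covers a single double bond going from Z to E, and here the sense is from E to Z. Read in reverse, the step from compound 2 to compound 3 points to a lower number in this assay. The data give no separate measure of the second double bond, so the range must stay wide on both sides. A modest step is expected, of the order of a 2.2-fold lower number from compound 3 to compound 4 (0.33 log units; beyond the scatter). For compound 4 the expected value is 20000 nM, with an estimated range from 7000 nM to 50000 nM.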

Compound 4, half-maximal inhibitory concentration: 18000 nM
Beside the measured number, compound 4's estimate is 1.1-fold (0.05 log units) above it; measured number inside the range.
By their numbers in this assay, from the lowest: compounds 2 and 4 (each within the scatter of the next); then compounds 1 and 3 (each within the scatter of the next).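

In this assay, among the compounds shown here, a 2.4-fold lower number from compound 3 to compound 4 (0.38 log units; beyond the scatter) is the first step to change two double bonds at once, and with no atoms or bonds altered, it can come only from configuration: the fact that compounds 3 and 4 differ only in the configuration as drawn. Taken alone, the double bond that separates the next pair has no readable effect, with a 1.3-fold higher number from compound 2 to compound 4 (0.11 log units; within the scatter), so a change in configuration does not by itself move the number beyond the scatter: the fact that compounds 2 and 4 differ only in the configuration as drawn. Compounds 2 and 4 share the geometry of the double bond that separates compound 2 from compound 3, so among these three isomers the difference beyond the scatter follows that one bond, and none of the three goes against this reading.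

Still open, from the compounds shown here alone, is how the double bond separating compound 2 from compound 4 behaves when the other double bond keeps its geometry from compound 3, since its single effect is read here only with the other as in compound 2. Also open, going by these compounds, is whether this dependence on geometry survives when the carbamate gives way to a primary amine or the methyl on the double bond to an ethyl group.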